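The source may report more compounds than this note shows. Statements on the series, on what has been measured and on what is new or still open speak of the compounds shown alone.

Measured compounds, activity in a functional assay, tested at 10 uM; on this read-out lower numbers stand for a weaker effect and higher numbers for a stronger effect at the one concentration tested:
- compound 1 `O=C(O)c1cn(Cc2ccc(O)c(O)c2)c2ccccc2c1=O`: 44.9%
- compound 2 `O=C(NO)c1cn(Cc2ccc(Cl)cc2)c2ccccc2c1=O`: "not determined" (no result reported)
- compound 3 `O=C(NO)c1cn(Cc2ccc(O)cc2)c2ccccc2c1=O`: 32.3%

Compound 3 holds the lower of the two numbers in hand. In this assay compound 1 gives 44.9% and compound 3 gives 32.3%; the gap between these two lies beyond the usual scatter, but the two compounds differ in two places, so the gap cannot be assigned to either change alone. Compound 2 contributes no number.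

Compound 4 `O=C(NO)c1cn(Cc2ccc(O)c(O)c2)c2ccccc2c1=O` has not yet been tested in this assay. Against compound 3 the change is hydroxy in place of hydrogen on an aromatic carbon, that is 4-hydroxyphenyl to 3,4-dihydroxyphenyl. The same 3,4-dihydroxyphenyl group is present in compound 1, whose 44.9% is the higher of the two numbers, which gives some ground for expecting a rise rather than a fall.

The step from compound 3 to compound 4 is therefore expected to be a modest increase, a number 9.7 percentage points higher from compound 3 to compound 4 (within the scatter), roughly at the edge of the scatter. For compound 4 the estimate in this assay is 42%, with a range from 26% to 58%.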

Compound 4, a percentage reported as activity, at one concentration (the size of the read-out at that concentration, not a potency): 51.1%
Compound 4: middle estimate off by 9.1 percentage points, on the low side; the measured number falls inside the stated range.
By their numbers in this assay, from the lowest: compound 3; then compounds 1 and 4 (each within the scatter of the next).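

In this assay, hydroxy in place of hydrogen on the aromatic carbon ortho to a hydroxy group, which turns 4-hydroxyphenyl into 3,4-dihydroxyphenyl, gives a number 18.8 percentage points higher from compound 3 to compound 4 (beyond the scatter), so this position responds to the change. With 3,4-dihydroxyphenyl held fixed, hydroxyamino in place of hydroxy on the carbonyl carbon gives a number 6.2 percentage points higher from compound 1 to compound 4 (within the scatter), so among these compounds the earlier gap between compound 1 and compound 3 follows the ring hydroxy rather than this swap. No measurement here explains the effect of the added hydroxy.

As far as these compounds go, whether the rise is particular to hydroxy remains open, since a methoxy group or an amine on the same aromatic carbon would be needed to tell. From the compounds shown here alone, the read-out also stands at one concentration, so potency across the series remains open.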